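Swapping the Biaryl Substituent on a Thromboxane Receptor Antagonist

The compounds below may be only part of what the source reports. "The series", "measured", "known", "first", "only" and "open" are said of these compounds alone.

Measured compounds:
- compound 1, `O=C(O)CC/C=C\CO[C@H]1C(OCc2ccc(-c3ccccc3CCO)cc2)CC[C@@H]1N1CCCCCC1`, 2 nM
- compound 2, `O=C(O)CC/C=C\CO[C@H]1[C@H](OCc2ccc(-c3ccccc3CO)cc2)CC[C@@H]1N1CCCCCC1`, 6.31 nM
- compound 3, `CS(=O)(=O)Nc1ccccc1-c1ccc(COC2CC[C@H](N3CCCCCC3)[C@H]2OC/C=C\CCC(=O)O)cc1`, 10 nM

In a functional assay on blood for antagonist activity at thromboxane A2 receptor (Homo sapiens) (a lower number here means tighter binding, a higher number weaker binding), compound 3 gives 10 nM, the highest of the three numbers. Its nearest neighbour is compound 2, which in this assay gives 6.31 nM, a gap that lies within the scatter. The furthest is compound 1, which in this assay gives 2 nM. Among the compounds with values here, the only measured step that touches the methanesulfonamido group is a 5.0-fold higher number from compound 1 to compound 3 (0.70 log units; beyond the scatter), a modest but real move toward weaker binding.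

Compound 4, `O=C(O)CC/C=C\CO[C@H]1C(OCc2ccc(-c3ccccc3CO)cc2)CC[C@@H]1N1CCCCCC1`, differs from compound 3 by hydroxymethyl in place of methanesulfonamido on an aromatic carbon. Within the data shown here, no measured step covers exactly this exchange. What the numbers do show is that compound 2, which carries the same hydroxymethyl group on a core with fully defined stereochemistry, gives 6.31 nM, and that removing the methanesulfonamido group in favour of a hydroxyalkyl group reversed the direction of the step from compound 1 to compound 3. Compound 4 is therefore expected to sit close to compound 2, with a step of about a 1.7-fold lower number from compound 3 to compound 4 (0.22 log units; within the scatter) relative to compound 3. The estimate for compound 4 in this assay is 6 nM, within a range from 2.5 nM to 15 nM.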

Compound 4, dissociation constant: 3.16 nM
Beside the measured number, compound 4's estimate is 1.9-fold (0.28 log units) above it; the range from low to high includes it.
By their numbers in this assay, from the lowest: compounds 1, 4, 2 and 3 (each within the scatter of the next, the first and the last beyond it).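

In this assay, replacing methanesulfonamido with hydroxymethyl on the aromatic carbon gives a 3.2-fold lower number from compound 3 to compound 4 (0.50 log units; beyond the scatter), so a second hydroxyalkyl group now stands apart from methanesulfonamido in the same direction as the 2-hydroxyethyl group of compound 1, and that earlier gap no longer rests on one compound. Hydroxy in place of hydroxymethyl on the saturated chain carbon bound to the aromatic carbon gives a 1.6-fold higher number from compound 1 to compound 4 (0.20 log units; within the scatter), so the 2-hydroxyethyl and hydroxymethyl groups cannot be told apart in this assay, and the length of the chain across this pair has no readable effect. The step of a 2.0-fold lower number from compound 2 to compound 4 (0.30 log units; within the scatter) cannot be read as an effect of configuration at the ring carbon, owing to this: the fact that one of compounds 2 and 4 is drawn with a defined configuration and the other without, at the place where they differ.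

The compounds shown leave open whether the free hydroxy group itself is needed at this place, which a methoxymethyl group or an aminomethyl group would test. They also leave open whether a longer chain, such as 3-hydroxypropyl, or a carboxylic acid on the same aromatic carbon would stay within the scatter of compound 1.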